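The compounds below may be only part of what the source reports. "The series", "measured", "known", "first", "only" and "open" are said of these compounds alone.

Two related compounds have been measured so far in a functional assay on NT2 cells (Homo sapiens) for inhibition; on this read-out lower numbers stand for stronger inhibition and higher numbers for weaker inhibition. Compound 1 `CCCCCCN(C)CNCC(=O)[C@H](CC(=O)O)NC(=O)C(CC)n1cc(C(C)(CC)CC)nc(NCc2nonc2C)c1=O` gives 0.025 nM, and compound 2 `CCC(C(=O)N[C@@H](CC(=O)O)C(=O)CSCc1ccccc1)n1ccnc(NCc2cccs2)c1=O` gives 4.56 nM. Compound 2 therefore has the higher number of the two and is the weaker inhibitor, by a gap well beyond the usual scatter. The two compounds differ in several places, so this gap does not show what any single change does. Compound 3 `CCC(C(=O)N[C@@H](CC(=O)O)C(=O)CSCc1ccccc1)n1ccnc(NCC2COc3ccccc3O2)c1=O` is compound 2 with one change: 2,3-dihydro-1,4-benzodioxin-2-yl in place of thiophen-2-yl on a saturated chain carbon bound to a nitrogen on an aromatic ring. In words, this puts 2,3-dihydro-1,4-benzodioxin-2-yl in place of thiophen-2-yl on a saturated chain carbon bound to a nitrogen on an aromatic ring. Among the measured compounds shown here, no measured pair shows this swap, so only a small upward step, within the scatter, is expected, and with wide uncertainty. The expected step is a 1.3-fold higher number from compound 2 to compound 3 (0.12 log units; within the scatter). For compound 3 the estimated value is 6 nM, with an expected range of 1.5 nM to 25 nM.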

Compound 3, half-maximal inhibitory concentration: 30 nM
Beside the measured number, compound 3's estimate is 5.0-fold (0.70 log units) below it; measured number outside the range, above it.
By their numbers in this assay, from the lowest: compound 1; then compound 2; then compound 3.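

Among the compounds shown here, this is the first comparison that differs in only one place, and it shows that the group on a saturated chain carbon bound to a nitrogen on an aromatic ring matters in this assay. Putting 2,3-dihydro-1,4-benzodioxin-2-yl in place of thiophen-2-yl gives a 6.6-fold higher number from compound 2 to compound 3 (0.82 log units; beyond the scatter), so compound 3 is a weaker inhibitor than compound 2. Nothing available explains why this swap weakens inhibition.

On these data alone, it remains open whether a single-ring group such as furan-2-yl or pyridin-2-yl in this place would give a number closer to that of compound 2 or to that of compound 3. As far as these compounds go, it is also open whether the same swap would have a similar effect on the very different background of compound 1.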